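Oxime in place of the ring formyl group of compound 1

This account rests on a few compounds, and the source may have more. Where it says the series, first, only, none or still open, it means among the compounds named here.

Compound 1, `CC(C)=CCC[C@]1(C)/C=C/[C@@H](OC(=O)C=C(C)C)[C@](C)(O)/C=C/C(=O)/C(C=O)=C\C1`: in a functional assay on MCF7 cells (Homo sapiens) for antiproliferative activity, read by MTT assay, with a stated time of 48 h (a higher number here means a weaker inhibitor, a lower number a stronger inhibitor), compound 1 gives 12600 nM.
Compound 2, `CC(C)=CCC[C@]1(C)/C=C/[C@@H](OC(=O)C=C(C)C)[C@](C)(O)/C=C/C(=O)/C(CN(C)C)=C\C1`: compound 2 gives 690 nM.
Compound 3, `CC(C)=CCC[C@]1(C)/C=C/[C@@H](OC(=O)C=C(C)C)[C@](C)(O)/C=C/C(=O)/C(C[Si](C)(C)C(C)(C)C)=C\C1`: compound 3 gives 6040 nM.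

Compound 1 stands highest of the three numbers, the weakest of the measured set, with compound 3 nearest and compound 2 furthest from it. Compound 4, `CO/N=C/C1=C/C[C@](C)(CCC=C(C)C)/C=C/[C@@H](OC(=O)C=C(C)C)[C@](C)(O)/C=C/C1=O`, differs from compound 1 in one place: a group of 4 heavy atoms (2 carbon, 1 nitrogen, 1 oxygen; no ring) in place of a group of 2 heavy atoms (1 carbon, 1 oxygen; no ring), on a double-bonded ring carbon.

Going by the values given here, two measured steps bear on this, each removing the same formyl from the same double-bonded ring carbon: an 18-fold lower number from compound 1 to compound 2 (1.26 log units; beyond the scatter) and a 2.1-fold lower number from compound 1 to compound 3 (0.32 log units; beyond the scatter). Both steps lower the number, but by very different amounts, and the gap between the two replacements, an 8.8-fold higher number from compound 2 to compound 3 (0.94 log units; beyond the scatter), shows that what enters matters more than the mere loss of formyl. The entering group of compound 4 is small, keeps one double bond outside aromatic rings and carries no donor and two acceptors; it resembles neither the charged-amine-like group of compound 2 nor the bulky silyl chain of compound 3. A modest fall in the number is therefore expected, closer in size to the step seen for compound 3 than to that for compound 2.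

Compound 4 is estimated at 4500 nM, with a range from 1500 nM to 12000 nM, which corresponds to an expected step of a 2.8-fold lower number from compound 1 to compound 4 (0.45 log units; beyond the scatter).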

Compound 4, half-maximal inhibitory concentration: 2510 nM
Estimate against measurement, compound 4: 1.8-fold (0.25 log units) above, and the stated range covers the measured number.
By their numbers in this assay, from the lowest: compound 2; then compound 4; then compound 3; then compound 1.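

In this assay, the oxime of compound 4 is a third replacement for formyl on this double-bonded ring carbon that lowers the number, with a 5.0-fold lower number from compound 1 to compound 4 (0.70 log units; beyond the scatter) as its step, so all three groups shown at this place improve on formyl. The oxime also falls clearly between the two earlier replacements, with a 2.4-fold lower number from compound 3 to compound 4 (0.38 log units; beyond the scatter) on one side and a 3.6-fold higher number from compound 2 to compound 4 (0.56 log units; beyond the scatter) on the other; the second of these steps joins two entering groups of 4 heavy atoms each, so heavy-atom count alone does not set the number at this position. Nothing measured here accounts for the differences among these groups.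

The compounds shown leave open which part of the oxime carries the gain, and a free hydroxyimino group or a longer alkyl chain on the oxime oxygen would separate the oxime itself from its methyl. They also leave open how far the series extends on the amine side, where a pyrrolidin-1-ylmethyl or morpholin-4-ylmethyl group would test whether the step to compound 2 holds for other amines, and how a carboxylic acid would compare with formyl at this carbon.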